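A few compounds are considered here, and "the series" means these few. Any claim that something is new, unique, unknown or untested is made for them only; others in the source may bear on it.

Measured so far in a functional assay on HeLa cells (Homo sapiens) for antiproliferative activity, read by MTT assay, with a stated time of 48 h; on this read-out higher numbers stand for weaker inhibition and lower numbers for stronger inhibition:
compound 1 (`CCOc1cc(-c2ccc3cc[nH]c3c2)cn2c(-c3cc(OC)c(OC)c(OC)c3)nnc12`) gives 272 nM
compound 2 (`COc1cc(-c2nnc3c(OC4COC4)cc(-c4ccc5[nH]ccc5c4)cn23)cc(OC)c1OC`) gives 2780 nM
compound 3 (`COc1cc(-c2nnc3c(OC4CC4)cc(-c4ccc5[nH]ccc5c4)cn23)cc(OC)c1OC`) gives 119 nM

Compound 1 holds the second highest of these three numbers, with a value above that of compound 3 and below that of compound 2. The unmeasured compound 4 (`CCOc1cc(-c2ccc3ccn(C)c3c2)cn2c(-c3cc(OC)c(OC)c(OC)c3)nnc12`) differs from compound 1 by methyl in place of hydrogen on an aromatic nitrogen and so has methyl in place of hydrogen on an aromatic nitrogen, which turns 1H-indol-6-yl into 1-methyl-1H-indol-6-yl.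

Going by the values given here, only one measured step is available, and it bears on this change only indirectly: a 23-fold lower number from compound 2 to compound 3 (1.37 log units; beyond the scatter) with cyclopropyl in place of oxetan-3-yl on an oxygen on an aromatic ring. Among the compounds with values here, that step shows how far a number can move in this set, but it lies at a different place, and no measured pair tests the aromatic nitrogen. The data therefore give no direction, and no step beyond the scatter is expected in this assay on present evidence. The step estimated here is a 1.1-fold lower number from compound 1 to compound 4 (0.04 log units; within the scatter) and it is only an expectation. For compound 4 the estimated value is 250 nM with an expected range from 80 nM to 800 nM around it.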

Compound 4, half-maximal inhibitory concentration: 240 nM
For compound 4 the middle estimate is 1.0-fold (0.02 log units) above the measured one, within the range that was stated.
By their numbers in this assay, from the lowest: compounds 3, 4 and 1 (each within the scatter of the next, the first and the last beyond it); then compound 2.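

In this assay, going by these compounds alone, the first pair to test the aromatic nitrogen shows a 1.1-fold lower number from compound 1 to compound 4 (0.05 log units; within the scatter), whereas the only earlier step lay on an oxygen on an aromatic ring. On the core of compound 1, then, the hydrogen on this nitrogen can be replaced by methyl, turning 1H-indol-6-yl into 1-methyl-1H-indol-6-yl, with no step beyond the scatter. Nothing in the available data explains why this read-out stays within the scatter.

The compounds shown leave open whether this nitrogen would accept more than methyl, such as a longer chain like n-butyl or a chain ending in an amine or a carboxylic acid. They also leave open whether methyl on the aromatic nitrogen would give a similar result in compound 2 or compound 3.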